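The source may hold more compounds than are shown below. What is called first, only, known or untested is meant among the compounds shown, and "the series" means these compounds.

Series notes, step from compound 2 to compound 3.

Compound 1 `CCCc1cc(N)c2cc(NC(=O)/C=C/c3ccc(N)cc3)ccc2n1` and compound 2 `CCCc1cc(N)c2cc(NC(=O)/C=C/c3ccc(O)cc3)ccc2n1` share one core and differ only at the far aromatic ring. In an assay on isolated protein for displacement of a labelled ligand from melanin-concentrating hormone receptor 1 (Homo sapiens) (on this read-out higher numbers stand for weaker inhibition and lower numbers for stronger inhibition), compound 1 gives 190 nM, while compound 2 gives 1100 nM. Among the measured compounds shown here, the single measured step is a 5.8-fold higher number from compound 1 to compound 2 (0.76 log units; beyond the scatter). On the two numbers shown, compound 2 stands at the weaker end, with compound 1 the only neighbour.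

Compound 3 `CCCc1cc(N)c2cc(NC(=O)/C=C/c3ccccc3)ccc2n1` is the next point on the same ring. The change from compound 2 is hydrogen in place of hydroxy on an aromatic carbon. For the measured compounds named here, no measured step removes the hydroxy outright, so the only bearing comes from compound 2 against compound 1, where a 5.8-fold higher number from compound 1 to compound 2 (0.76 log units; beyond the scatter) shows this position is sensitive to what sits there. With that single step the direction is open; the expected outcome in this assay is a small step, a 1.4-fold higher number from compound 2 to compound 3 (0.13 log units; within the scatter), within the scatter or just outside it. Compound 3 is therefore estimated at 1500 nM, in the range 500 nM to 5000 nM.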

Compound 3, half-maximal inhibitory concentration: 1000 nM
The estimate for compound 3 lay 1.5-fold (0.18 log units) above the measured number; measured number inside the range.
By their numbers in this assay, from the lowest: compound 1; then compounds 3 and 2 (each within the scatter of the next).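

Going from 4-hydroxyphenyl to phenyl gives a 1.1-fold lower number from compound 2 to compound 3 (0.04 log units; within the scatter) in this assay, so on this read-out the hydroxy cannot be told apart from hydrogen at this position. Hydrogen in place of amino gives a 5.3-fold higher number from compound 1 to compound 3 (0.72 log units; beyond the scatter), which shows that the earlier step from compound 1 marks out the amino group in particular, since compound 1 now stands apart from both compound 2 and compound 3. Nothing on hand explains why the amino group stands apart.

From the compounds shown here alone, whether this holds only for the free amino group stays open, since a methylamino, a dimethylamino, an aminomethyl or a carboxylic acid at the same place could separate it from other groups. Going by these compounds, whether the same order holds with a chain other than propyl on the shared core also remains open.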